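The source may hold more compounds than are shown below. What is called first, only, known or untested is meant among the compounds shown, and "the series" means these compounds.

Working notes on an in vitro ADME assay on microsomes from liver (Macaca mulatta) for metabolic stability (on this read-out lower numbers stand for a shorter-lived compound and higher numbers for a longer-lived compound), for this series, which shares one core and varies the saturated ring and the benzyl group. Compound 1 `CS(=O)(=O)Nc1ccc2c(c1)S(=O)(=O)N=C(C1=C(O)[C@H]3CCC[C@H]3N(Cc3ccc(F)c(F)c3)C1=O)N2` is reported in this assay only as a limit, > 1 h. Compound 2 `CS(=O)(=O)Nc1ccc2c(c1)S(=O)(=O)N=C(c1c(O)c3cccn3n(Cc3ccc(F)cc3)c1=O)N2` likewise comes back from this assay as a limit, > 1 h. Compound 3 `CS(=O)(=O)Nc1ccc2c(c1)S(=O)(=O)N=C(C1=C(O)[C@H]3CCCC[C@H]3N(Cc3ccc(F)cc3)C1=O)N2` also sits at a limit in this assay, > 1 h. Compound 3 therefore stands exactly where the whole measured set stands, at the ceiling of the read-out: the limit of > 1 h in this assay, at which 3 of the 3 values shown sit. Among the compounds with values here, no pair of measured compounds differs in a single place, so no measured step is available to calibrate the next change.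

Compound 4 `CS(=O)(=O)Nc1ccc2c(c1)S(=O)(=O)N=C(C1=C(O)[C@@H]3CCCC[C@@H]3N(Cc3ccc(F)cc3)C1=O)N2` differs from compound 3 only in configuration: the two compounds have the same atoms and bonds and differ only in configuration as drawn: 2 of 2 stereo elements differ (all stereocentres are inverted: mirror images); a stereocentre at a saturated ring carbon is drawn S in compound 3 and R in compound 4; a stereocentre at a saturated ring carbon is drawn R in compound 3 and S in compound 4. No atom or bond leaves or enters. Within the data shown here, nothing in the measured set addresses what inversion of both stereocentres does in this assay, and every value so far is a limit, so the expected step from compound 3 to compound 4 is none beyond the scatter, estimated as a step that the limit leaves unreadable from compound 3 to compound 4. Compound 4 is accordingly expected to give about 1.5 h in this assay, with a range from 0.5 h to 4 h, and with a good chance that the read-out again returns only the limit rather than a number.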

Compound 4, half-life: > 1 h
Compound 4 was reported as a limit; the forecaster's own chance of this, stated with the estimate: 70%; the middle value does not contradict the limit.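

No step can be read from compound 3 to compound 4 in this assay, because both compounds are reported only as limits: the limit of > 1 h in this assay, at which 4 of the 4 values shown sit.

The compounds shown leave open whether inverting both stereocentres changes the half-life at all, and how the half-lives of these compounds compare with one another.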